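A fluoropyridine in place of a cyanopyridine

This account rests on a few compounds, and the source may have more. Where it says the series, first, only, none or still open, it means among the compounds named here.

In a functional assay on HEK293 cells for agonist activity at Bombesin receptor subtype-3 (Homo sapiens), read by luminescence and calcium flux, with a stated time of 10 min (on this read-out higher numbers stand for an effect only at larger amounts of compound and lower numbers for an effect already at smaller amounts), compound 1 `CCC(C)(C)Cc1c[nH]c(CCc2ccc(-c3ccncc3)cc2)n1` gives 305 nM, and compound 2 `CCC(C)(C)Cc1c[nH]c(CCc2ccc(-c3cccc(C#N)n3)cc2)n1` gives 193 nM. Compound 2 stands alongside compound 1, the two separated only by a 1.6-fold lower number from compound 1 to compound 2 (0.20 log units; within the scatter). Compound 3 `CCC(C)(C)Cc1c[nH]c(CCc2ccc(-c3ccc(F)cn3)cc2)n1` differs from compound 2 by 5-fluoropyridin-2-yl in place of 6-cyanopyridin-2-yl on an aromatic carbon. For the measured compounds named here, the single measured step, which also changed this aryl group, stayed within the scatter, so no step beyond the scatter is expected in this assay from the move to 5-fluoropyridin-2-yl. For compound 3 the expected step is a 1.3-fold higher number from compound 2 to compound 3 (0.11 log units; within the scatter). Compound 3 is therefore estimated at 250 nM, with a range from 100 nM to 700 nM.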

Compound 3, half-maximal effective concentration: 66 nM
Compound 3: middle estimate off by 3.8-fold (0.58 log units), on the high side, outside the stated range (below it).
By their numbers in this assay, from the lowest: compound 3; then compounds 2 and 1 (each within the scatter of the next).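

In this assay this aryl group on the ring of carbon only turns out to matter: a 2.9-fold lower number from compound 2 to compound 3 (0.47 log units; beyond the scatter), and a 4.6-fold lower number from compound 1 to compound 3 (0.66 log units; beyond the scatter). For the compounds shown here, these are the first steps here beyond the scatter, and both lead to the 5-fluoropyridin-2-yl of compound 3. Nothing shown explains why this group gives the lower number.

On these data alone, the group and the place of its substituent change together, so the share of the fluorine alone stays open. So does whether a chlorine or a methoxy group on the same pyridine would give a similar number.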